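Chloro in place of fluoro on compound 1

The compounds below may be only part of what the source reports. "The series", "measured", "known", "first", "only" and "open" are said of these compounds alone.

In an ADME assay on MT4 cells (Homo sapiens) for cytotoxicity, read by spectrophotometry, with a stated time of 5 days (a lower number here means that less compound is tolerated, a higher number that more compound is tolerated), compound 1 (`CONC(=S)N/N=C1\C(=O)N(CN(C)C)c2ccc(F)cc21`) gives 560000 nM and sits level with compound 2 (`CN(C)CN1C(=O)/C(=N\NC(=S)NO)c2cc(F)ccc21`) at 599000 nM as the upper pair of the three measured. Compound 3 (`CCn1cc(C(=O)O)c(=O)c2cc(F)c(N3CCN(CN4C(=O)/C(=N\NC(=S)NO)c5cc(C)ccc54)C(C)C3)c(F)c21`) gives the lowest number at 244000 nM but differs from compound 1 in several places, so it offers little guidance on a single substituent.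

Compound 4 (`CONC(=S)N/N=C1\C(=O)N(CN(C)C)c2ccc(Cl)cc21`) carries chloro in place of fluoro on an aromatic carbon of the shared core (chloro in place of fluoro on an aromatic carbon) with the rest of compound 1 unchanged. For the measured compounds named here, no measured step exchanges this halogen. Going by the values given here, the only step available is a 1.1-fold higher number from compound 1 to compound 2 (0.03 log units; within the scatter) and it involves a different place, hydrogen in place of methyl on an oxygen, so it bears only indirectly. With nothing pointing to a large shift, no step beyond the scatter is expected, and the estimated change is a 1.1-fold lower number from compound 1 to compound 4 (0.05 log units; within the scatter) in either reading of a small move. In this assay the estimate for compound 4 is 500000 nM (expected range 220000 nM to 850000 nM).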

Compound 4, half-maximal cytotoxic concentration: 552000 nM
Compound 4: middle estimate off by 1.1-fold (0.04 log units), on the low side; the range from low to high includes it.
By their numbers in this assay, from the lowest: compound 3; then compounds 4, 1 and 2 (each within the scatter of the next).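

In this assay, for the compounds shown here, chloro in place of fluoro on an aromatic carbon of the shared core gives a 1.0-fold lower number from compound 1 to compound 4 (0.01 log units; within the scatter), which is the only direct reading of this position, as the earlier step concerned the methyl on an oxygen. With the rest of compound 1 unchanged, this read-out does not separate the two halogens at this carbon, so fluoro and chloro can be treated as interchangeable here for this assay alone. No supporting data bear on why the two halogens read alike.

From the compounds shown here alone, whether a larger or different group on this carbon, such as an amine, a carboxylic acid or a longer chain, would shift the number remains open. Also open, going by these compounds, is whether the halogen exchange reads the same on compound 2, which carries hydrogen in place of methyl on the oxygen.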